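This account rests on a few compounds, and the source may have more. Where it says the series, first, only, none or still open, it means among the compounds named here.

Compound 1 `O=C(CCC1=CCCN(Cc2ccc(F)cc2)C1=O)NO`: "not determined" (no result reported)
Compound 2 `CC(=O)Nc1ccc(CN2CCC=C(CCC(=O)NO)C2=O)cc1`: > 10000 nM
Compound 3 `Cc1ccc(S(=O)(=O)Nc2ccc(CN3CCC=C(CCC(=O)NO)C3=O)cc2)cc1`: 1800 nM

Among the compounds with values here, in a functional assay on PC-3 cells (Homo sapiens) for inhibition, read by sulforhodamine B assay (on this read-out higher numbers stand for weaker inhibition of growth and lower numbers for stronger inhibition of growth), compound 3 gives 1800 nM, the only true number. For compound 2 the entry > 10000 nM is a limit of the assay and not a number.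

Compound 4 `O=C(CCC1=CCCN(Cc2ccc(NC(=O)c3ccccc3)cc2)C1=O)NO` carries benzoyl in place of (4-methylphenyl)sulfonyl on a nitrogen on an aromatic ring. Within the data shown here, one measured step bears on this change: an at least 5.5-fold lower number from compound 2 to compound 3 (0.74 log units; beyond the scatter), where (4-methylphenyl)sulfonyl replaced acetyl on that nitrogen. Benzoyl shares its carbonyl with the acetyl of compound 2 and its aromatic ring with the group of compound 3, so a slight upward drift in this assay, not beyond the scatter, is expected. The expected change is a 1.7-fold higher number from compound 3 to compound 4 (0.22 log units; within the scatter). Compound 4 is estimated at 3000 nM, with an expected range of 1000 nM to 10000 nM.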

Compound 4, concentration for 50% growth inhibition: > 10000 nM
Compound 4 was reported as a limit; the forecaster's own chance of this, stated with the estimate: 25%; middle value at least 3.3-fold (0.52 log units) away from the limit.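

On the nitrogen on an aromatic ring, benzoyl in place of (4-methylphenyl)sulfonyl gives an at least 5.5-fold higher number from compound 3 to compound 4 (0.74 log units; beyond the scatter) in this assay, so an aromatic ring in this group does not by itself keep the growth inhibition of compound 3. Of the three groups compared on this nitrogen, only (4-methylphenyl)sulfonyl gives a true number, while the carbonyl-linked acetyl and benzoyl both end at a limit. The step from compound 2 to compound 4 cannot be read, because both values are limits: the limit of > 10000 nM in this assay, at which 2 of the 4 values shown sit.

The compounds shown leave open whether methanesulfonyl or phenylsulfonyl on this nitrogen would match compound 3. They also leave open how much of its value depends on the sulfonyl link and how much on the methyl group.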